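Tertiary amide in place of secondary amide on the shared core

A few compounds are considered here, and "the series" means these few. Any claim that something is new, unique, unknown or untested is made for them only; others in the source may bear on it.

Of the compounds shown here, three sharing one core have been measured in a functional assay on the whole organism (strain Wistar) for inhibition, with Rattus norvegicus as the target, read by paw edema, with stated times of 60 min and 3 h, at a dose of 100 mg/kg by the oral route; a lower number here means less inhibition, a higher number more inhibition at the dose given (going by the name of the read-out). Compound 1 `CCNC(=O)CC1CCc2cc(OC)c(OC)cc21` gives 26.1%, compound 2 `CCCNC(=O)CC1CCc2cc(OC)c(OC)cc21` gives 29%, and compound 3 `COc1cc2c(cc1OC)C(CC(=O)NC(C)C)CC2` gives 30.4%. Compound 2 holds the second highest of the three numbers, yet every gap is within the scatter: a number 2.9 percentage points higher from compound 1 to compound 2 (within the scatter), a number 4.3 percentage points higher from compound 1 to compound 3 (within the scatter) and a number 1.4 percentage points higher from compound 2 to compound 3 (within the scatter) all fall inside the range that repeated measurements of this kind wander over, so the three are best read as alike.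

Compound 4 `COc1cc2c(cc1OC)C(CC(=O)N1CCOCC1)CC2` is the next member. From compound 2 the change is morpholin-4-yl in place of propylamino on a carbonyl carbon. Every measured step bears on it in the loose sense that each also alters the group on the amide-type nitrogen, and none moved the number beyond the scatter. None of them, however, replaces the propylamino group with a ring, and none removes the hydrogen-bond donor, so the available steps give no direct guide for that part of the change.

On this basis no step beyond the scatter is expected in this assay; the step of a number 1 percentage points lower from compound 2 to compound 4 (within the scatter) is estimated, with a wide allowance. Compound 4 is therefore expected to give about 28%, within a range from 14% to 42%.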

Compound 4, a percentage reported as inhibition, in the whole organism at one dose (the size of the read-out at that dose, not a potency): 19.6%
Compound 4: the middle estimate sits 8.4 percentage points above what was measured; measured number inside the range.
By their numbers in this assay, from the lowest: compounds 4, 1, 2 and 3 (each within the scatter of the next, the first and the last beyond it).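

Among the compounds shown here, on a carbonyl carbon, morpholin-4-yl is the first change in this assay to produce a step beyond the scatter: in place of isopropylamino it gives a number 10.8 percentage points lower from compound 3 to compound 4 (beyond the scatter) and so separates a pair of compounds for the first time. The signal is modest and rests on that one pair, since the same ring in place of the other two groups gives a number 9.4 percentage points lower from compound 2 to compound 4 (within the scatter) and a number 6.5 percentage points lower from compound 1 to compound 4 (within the scatter) as the remaining comparisons. Nothing measured here explains the step from compound 3 to compound 4.

The change brings in a ring and its oxygen and removes the amide hydrogen all at once, so the compounds shown leave open which of these goes with the lower number in compound 4. A piperidin-1-yl group, which has a six-membered ring without the oxygen, and a dimethylamino group, which has no amide hydrogen and no ring, would help to tell these apart, and each reading here still comes from a single oral dose.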